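This account rests on a few compounds, and the source may have more. Where it says the series, first, only, none or still open, it means among the compounds named here.

Three compounds share one core, and all three have been tested in an ADME assay on PANC-1 cells (Homo sapiens) for cytotoxicity, read by MTT assay; on this read-out higher numbers stand for lower toxicity in this test and lower numbers for higher toxicity in this test. Compound 1, `COc1ccccc1-c1nnc(-c2sc(-c3cccnc3)nc2C)o1`, gives in this assay > 100 ug/mL, which is a limit of the assay and not a number. Compound 2, `Cc1nc(-c2cccnc2)sc1-c1nnc(-c2ccccc2)o1`, gives > 100 ug/mL, again only a limit. Compound 3, `Cc1nc(-c2cccnc2)sc1-c1nnc(-c2ccc(Cl)cc2)o1`, likewise gives > 100 ug/mL, a limit as well. Among the measured compounds shown here, because every value sits at the limit of > 100 ug/mL in this assay, at which 3 of the 3 values shown sit, no step between these compounds can be sized: a step that the two limits leave unreadable from compound 1 to compound 2, a step that the two limits leave unreadable from compound 1 to compound 3 and a step that the two limits leave unreadable from compound 2 to compound 3 all stay unreadable. Compound 3 therefore stands where the other two stand, at the limit, with no ordering among them. Compound 4, `Cc1nc(-c2cccnc2)sc1-c1nnc(-c2ccc(O)cc2)o1`, differs from compound 3 in one place: hydroxy in place of chloro on an aromatic carbon. For the measured compounds named here, none of the measured steps has a readable size; they cannot say how such a change moves the read-out, and show only that three different groups on this part of the molecule all leave the value at the limit. No step beyond the scatter is therefore expected for a step that the limit leaves unreadable from compound 3 to compound 4. Compound 4 is estimated at 150 ug/mL, in the range 70 ug/mL to 400 ug/mL, most likely again reported only as a limit.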

Compound 4, half-maximal cytotoxic concentration: > 100 ug/mL
Compound 4 gave a limit, no number; the forecaster's own chance of this, stated with the estimate: 85%; the middle value lies beyond the limit too.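

Among the compounds shown here, no step between compound 1, compound 2, compound 3 and compound 4 can be read in this assay, because all four values are limits of the assay and not numbers: the limit of > 100 ug/mL in this assay, at which 4 of the 4 values shown sit. The compounds shown leave open whether these four differ at all in toxicity in this test, and at what concentration any of them would show it.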